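From 2-fluorophenyl to 3-bromophenyl: working notes

The source may hold more compounds than are shown below. What is called first, only, known or untested is meant among the compounds shown, and "the series" means these compounds.

Of the compounds shown here, two have been read in an ADME assay on MDBK cells (Bos taurus) for cytotoxicity; on this read-out lower numbers stand for higher toxicity in this test and higher numbers for lower toxicity in this test. Compound 2 (`Fc1ccccc1Cn1ccc2nc(-c3ccccc3)nc-2c1`) gives > 100000 nM, which is a limit of the assay and not a number. Compound 1 (`Fc1cccc(F)c1Cn1cccc2nc(-c3c(F)cccc3F)nc1-2`) gives > 100000 nM, also a limit. Compound 2 therefore has no exact value and shares its position with compound 1, both standing at the limit of > 100000 nM in this assay, at which 2 of the 2 values shown sit.

Compound 3 (`Brc1cccc(Cn2ccc3nc(-c4ccccc4)nc-3c2)c1`) carries 3-bromophenyl in place of 2-fluorophenyl on a saturated chain carbon bound to an aromatic nitrogen. Within the data shown here, no measured step between compounds is available, so the data give no direct size for a change of this kind.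

No step beyond the scatter is expected in this assay, and no direction is assigned. This expectation rests on compound 2 at > 100000 nM, and compound 3 may well return only a limit too. The expected step of a number no higher from compound 2 to compound 3 (the limit leaves the size open) is therefore a cautious estimate. For compound 3 the estimated value is 100000 nM, with an expected range of 40000 nM to 200000 nM.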

Compound 3, half-maximal cytotoxic concentration: 85000 nM
Beside the measured number, compound 3's estimate is 1.2-fold (0.07 log units) above it, and the stated range covers the measured number.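

In this assay, 3-bromophenyl in place of 2-fluorophenyl on a saturated chain carbon bound to an aromatic nitrogen gives an at least 1.1-fold lower number from compound 2 to compound 3 (0.07 log units; that floor lies within the scatter), the first step read at this position, though only as a floor. Compound 3 is also the only compound shown that returns a number, so the read-out can give an exact value for a compound of this series, while the other two stand at a limit of the assay: the limit of > 100000 nM in this assay, at which 2 of the 3 values shown sit.

As far as these compounds go, the true size of the step remains unknown, since one end of it is a limit and its floor alone does not show a real change in cytotoxicity at this position. The change replaces one whole group with another, so the compounds shown do not separate the exchange of fluorine for bromine from the shift in the group's numbering. From the compounds shown here alone, a 2-bromophenyl or 3-fluorophenyl group would be needed to part these two, and how an amine or a carboxylic acid on the same saturated chain carbon would read in this assay stays open.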